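One Fluoro Step from Compound 2

The compounds below may be only part of what the source reports. "The series", "measured", "known", "first", "only" and "open" are said of these compounds alone.

Compound 1 `COc1cc(N(CC2CC2)c2ccccc2)cnc1C(=O)[C@H]1C[C@@H]1C(=O)O` and compound 2 `COc1cc(N(CC2CC2)c2cccc(C(F)(F)F)c2)cnc1C(=O)[C@H]1C[C@@H]1C(=O)O` share one core and differ only in a trifluoromethyl in place of hydrogen on an aromatic carbon. In an ADME assay on cells (Hepatocyte, Homo sapiens) for metabolic stability, read by LC-MS, with a stated time of 60 min, tested at 1 uM (a higher number here means faster removal of the compound, a lower number slower removal), compound 1 gives 3 uL/min, while compound 2 gives 2.3 uL/min; the step from one to the other is a 1.3-fold lower number from compound 1 to compound 2 (0.12 log units; within the scatter). Compound 2 therefore holds the lower of the two numbers, but that gap lies within the scatter, so the two compounds cannot be told apart on this assay. A third member, compound 3 `COc1cc(N(CC(C)(C)O)c2cccc(C(F)(F)F)c2)cnc1C(=O)[C@H]1C[C@@H]1C(=O)O`, carries a different group on the nitrogen and has no result in this assay ("not determined" (no result reported)).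

The compound not yet measured is compound 4 `COc1cc(N(CC2CC2)c2cc(C(F)(F)F)ccc2F)cnc1C(=O)[C@H]1C[C@@H]1C(=O)O`. Its change from compound 2 is fluoro in place of hydrogen on an aromatic carbon. Among the measured compounds shown here, the only measured step that bears on this move is the one from compound 1 to compound 2, which placed another fluorine-bearing group on the same ring and produced a change within the scatter. On that basis compound 4 is expected to give a number in this assay close to that of compound 2, with a step of about a 1.1-fold higher number from compound 2 to compound 4 (0.04 log units; within the scatter), in no clear direction. The estimate for compound 4 is 2.5 uL/min, with a range from 1 uL/min to 6 uL/min.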

Compound 4, intrinsic clearance in a liver preparation (reported as CLH), per the amount of preparation that the assay uses: < 1.1 uL/min
Compound 4: no number, only a limit; the forecaster's own chance of this, stated with the estimate: 10%; middle value at least 2.2-fold (0.35 log units) away from the limit.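

The fluoro on an aromatic carbon, ortho to a large group and para to a trifluoromethyl group, gives a clear change on this ring in this assay: the step is an at least 2.0-fold lower number from compound 2 to compound 4 (0.32 log units; beyond the scatter). The earlier change on the same ring did not separate its two compounds, with a 1.3-fold lower number from compound 1 to compound 2 (0.12 log units; within the scatter), so this single added atom is the first change shown to move the read-out beyond the scatter. Compound 4 gives < 1.1 uL/min, which is a limit of the assay and not a number, so the step has a known minimum and no known full size, and compound 4 stands alone at that edge of the read-out: the limit of < 1.1 uL/min in this assay, at which 1 of the 4 values shown sits.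

The compounds shown leave open whether the step belongs to fluoro itself or to this place on the ring, as they include neither a chloro or nitrile group at this carbon nor a fluoro on another carbon of the ring. They also do not tell whether the same fluoro would give a similar step without the trifluoromethyl group, as in the ring of compound 1, or with the different nitrogen group of compound 3.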